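Series notes: from compound 2 to compound 4

A few compounds are considered here, and "the series" means these few. Any claim that something is new, unique, unknown or untested is made for them only; others in the source may bear on it.

Measured compounds:
- Compound 1, `Cc1ccccc1C(=O)c1ccn(-c2ccc3c(c2)B(O)OC3)c1`: in an ADME assay on L929 cells (Mus musculus) for cytotoxicity, read by resazurin assay, with a stated time of 72 h (a higher number here means a weaker inhibitor, a lower number a stronger inhibitor), compound 1 gives only a limit of the assay, > 10 ug/mL.
- Compound 2, `CCc1ccc(C(=O)c2ccn(-c3ccc4c(c3)B(O)OC4)c2)cc1`: in this assay compound 2 gives only a limit of the assay, > 10 ug/mL.
- Compound 3, `CC(=O)OCc1ccc(C(=O)c2ccn(-c3ccc4c(c3)B(O)OC4)c2)cc1`: in this assay compound 3 gives 10 ug/mL.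

Compound 2 stands at the limit, as does compound 1 (the limit of > 10 ug/mL in this assay, at which 2 of the 3 values shown sit); the step that the two limits leave unreadable from compound 1 to compound 2 thus cannot be read. The step of a number no higher from compound 2 to compound 3 (the limit leaves the size open) is open in size as well, since only the value of compound 3 is a number. No measured value among the three lies clearly away from the limit.

Compound 4, `NCCCC(=O)c1ccn(-c2ccc3c(c2)B(O)OC3)c1`, is not yet measured. It differs from compound 2 by 3-aminopropyl in place of 4-ethylphenyl on a carbonyl carbon. No measured step touches the group on the carbonyl carbon in this way: both steps shown concern substituents on an aromatic ring that remains in place, and both are of unreadable size. No direction is therefore indicated for the step to compound 4 beyond the scatter.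

Compound 4 is expected to give about 12 ug/mL in this assay, within 5 ug/mL to 30 ug/mL, which is expected to mean a step that the limit leaves unreadable from compound 2 to compound 4.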

Compound 4, half-maximal inhibitory concentration: > 10 ug/mL
Compound 4 ended at the assay's limit (the forecaster's own chance of this, stated with the estimate: 65%); the middle value lies beyond the limit too.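

Compound 4 gives > 10 ug/mL in this assay as a limit of the assay, not a number. The steps to compound 4 from compound 1 and compound 2 therefore cannot be read, and the result rests on one limit: the limit of > 10 ug/mL in this assay, at which 3 of the 4 values shown sit.

The compounds shown leave open whether 2-methylphenyl, 4-ethylphenyl and 3-aminopropyl on the carbonyl carbon differ at all in cytotoxicity.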